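The source may report more compounds than this note shows. Statements on the series, on what has been measured and on what is new or still open speak of the compounds shown alone.

Series values in a functional assay on MOLT-4 cells (Homo sapiens) for inhibition, read by MTT assay, with a stated time of 48 h; a higher number here means a weaker inhibitor, a lower number a stronger inhibitor:
- compound 1 `O=C(/C=C/c1ccccc1)c1ccc[nH]1`: > 100000 nM (a limit)
- compound 2 `O=C(/C=C/c1ccccc1Cl)c1ccco1`: 25000 nM
- compound 3 `O=C(/C=C/c1ccc(Cl)cc1)c1ccco1`: 23000 nM

Compound 3, at 23000 nM, lies within the scatter of compound 2 at 25000 nM, so the two cannot be told apart in this assay. Compound 1 gives only a limit, > 100000 nM.

The next compound to be measured is compound 4 `O=C(/C=C/c1ccccc1)c1ccco1`. It follows from compound 3 by one change, hydrogen in place of chloro on an aromatic carbon.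

Going by the values given here, no measured pair isolates this change, so the expectation is indirect. Both numerical values come from compounds carrying a chloro, namely compound 2 at 25000 nM and compound 3 at 23000 nM. Compound 1, which has no chloro, reaches only the limit of > 100000 nM. It also differs from these compounds elsewhere, so it is weak guidance, and a result reported only as a limit remains possible for compound 4.

A modest step toward a higher number is expected, possibly not much beyond the scatter. The estimated step is a 1.7-fold higher number from compound 3 to compound 4 (0.24 log units; within the scatter). The expected value for compound 4 is 40000 nM, with an estimated range of 18000 nM to 100000 nM.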

Compound 4, half-maximal inhibitory concentration: > 100000 nM
Compound 4: a limit, no number (the forecaster's own chance of this, stated with the estimate: 20%); middle value at least 2.5-fold (0.39 log units) away from the limit.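

In this assay, the chloro on this ring proves to matter: hydrogen in place of chloro on an aromatic carbon, para to a group of 9 heavy atoms, gives an at least 4.3-fold higher number from compound 3 to compound 4 (0.63 log units; beyond the scatter). The same replacement at the chloro position of the other measured chloro compound gives an at least 4.0-fold higher number from compound 2 to compound 4 (0.60 log units; beyond the scatter), so both chloro compounds give a numerical value and the compound without chloro on this furan-2-yl series does not. Compound 4 gives > 100000 nM, which is a limit and not a number.

Going by these compounds, whether a fluoro, a methoxy or an amine on the same aromatic carbon would also give a numerical value, and whether a chloro would do so on the 1H-pyrrol-2-yl compound, stays open. The step between compound 1 and compound 4, furan-2-yl in place of 1H-pyrrol-2-yl on a carbonyl carbon, cannot be read, and the full size of the chloro steps is also unknown, since both of these compounds sit at the same ceiling: the limit of > 100000 nM in this assay, at which 2 of the 4 values shown sit.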